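This account rests on a few compounds, and the source may have more. Where it says the series, first, only, none or still open, it means among the compounds named here.

Of the compounds shown here, three built on one shared core have so far been tested in a functional assay on SMMC-7721 cells (Homo sapiens) for antiproliferative activity, read by CCK-8 assay, with a stated time of 48 h; on this read-out lower numbers stand for stronger inhibition and higher numbers for weaker inhibition. Compound 1 `O=c1c2ccccc2[se]n1-c1nc(SCc2ccccc2)n[nH]1` gives 32000 nM. Compound 2 `CC(C)CSc1n[nH]c(-n2[se]c3ccccc3c2=O)n1` gives 35000 nM, and compound 3 `Cc1ccccc1CSc1n[nH]c(-n2[se]c3ccccc3c2=O)n1` gives 36200 nM. On these three numbers compound 2 sits in the middle, nearest to compound 3 and furthest from compound 1, and every gap among the three lies within the scatter of this assay.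

The next compound, compound 4 `CCCCCSc1n[nH]c(-n2[se]c3ccccc3c2=O)n1`, has not yet been measured. It differs from compound 2 in one place: butyl in place of isopropyl on a saturated chain carbon bound to a sulfur. Two of the measured steps touch the same saturated chain carbon bound to a sulfur: a 1.1-fold higher number from compound 1 to compound 2 (0.04 log units; within the scatter) and a 1.0-fold higher number from compound 2 to compound 3 (0.01 log units; within the scatter). Both lie within the scatter, so exchanging phenyl, isopropyl and 2-methylphenyl at that carbon has not moved this assay beyond its noise. The remaining step, a 1.1-fold higher number from compound 1 to compound 3 (0.05 log units; within the scatter), concerns an aromatic carbon and also lies within the scatter.

On that basis the expected step from isopropyl to butyl is no change at the digits printed from compound 2 to compound 4 (within the scatter), which is no change beyond the scatter. Compound 4 is therefore estimated at 35000 nM, with a range from 20000 nM to 60000 nM.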

Compound 4, half-maximal inhibitory concentration: 31400 nM
For compound 4 the middle estimate is 1.1-fold (0.05 log units) above the measured one; measured number inside the range.
By their numbers in this assay, from the lowest: compounds 4, 1, 2 and 3 (each within the scatter of the next).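

In this assay, butyl on a saturated chain carbon bound to a sulfur gives a 1.1-fold lower number from compound 2 to compound 4 (0.05 log units; within the scatter) and stands no further from the other two groups, with a 1.2-fold lower number from compound 3 to compound 4 (0.06 log units; within the scatter) and a 1.0-fold lower number from compound 1 to compound 4 (0.01 log units; within the scatter) as the remaining steps. Until now only isopropyl, phenyl and 2-methylphenyl had been seen at this carbon; butyl joins them, and all four compounds lie within the scatter of one another, so neither the exchange of isopropyl for butyl nor that of either aromatic group for butyl separates any pair. Nothing available here offers an explanation for why the numbers stay together.

The compounds shown leave open whether a longer chain such as octyl, or a chain ending in an amine or a carboxylic acid, would move the number at this carbon beyond the scatter. Within the data shown here, with every step so far inside that scatter, they also leave open whether any group at this carbon can shift this read-out at all.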